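Demethylation of the ring amine in the pyridyl bicyclic series

The compounds below may be only part of what the source reports. "The series", "measured", "known", "first", "only" and "open" are said of these compounds alone.

Of the compounds shown here, two of the shared core have been measured in an in vitro assay on SH-EP1 cells for displacement of a labelled ligand from Neuronal acetylcholine receptor; alpha4/beta2 (Homo sapiens); on this read-out higher numbers stand for weaker inhibition and lower numbers for stronger inhibition. Compound 1 `COc1cncc(C2=CC3CC(C2)CN(C)C3)c1` gives 0.6 nM. Compound 2 `CN1C[C@H]2C=C(c3cccnc3)C[C@H](C2)C1` gives 2.1 nM, the higher of the two numbers; compound 1 stands below it by a margin beyond the scatter. Compound 3 `C1=C(c2cccnc2)C[C@H]2CNC[C@@H]1C2` is not yet measured. It differs from compound 2 by hydrogen in place of methyl on an amine nitrogen in a ring. Among the measured compounds shown here, no step between measured compounds bears on this change, so the expectation for this assay rests on the change alone: a step of small to moderate size, most probably toward a lower number, though an outcome inside the scatter would not surprise. Compound 3 is therefore expected to give 1.2 nM, with a range of 0.4 nM to 4 nM. The step this estimate means, a 1.8-fold lower number from compound 2 to compound 3 (0.24 log units; within the scatter), is expected to sit near the edge of the scatter.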

Compound 3, inhibition constant: 0.2 nM
Estimate against measurement, compound 3: 6.0-fold (0.78 log units) above; measured number below the stated range.
By their numbers in this assay, from the lowest: compound 3; then compound 1; then compound 2.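

In this assay the amine nitrogen in the ring proves to be a sensitive position: hydrogen in place of methyl gives an 11-fold lower number from compound 2 to compound 3 (1.02 log units; beyond the scatter) and thus a large step, well clear of the scatter. Among the compounds shown here, the two earlier compounds both carry the methyl, so they could say nothing about this nitrogen; the change now stands as the only single-place comparison. Nothing in the data shown accounts for the size of this step.

Open, from the compounds shown here alone, is how the read-out responds to other groups on this nitrogen, such as an ethyl or a benzyl group. Also open, going by these compounds, is whether hydrogen in place of methyl gives a step of similar size on the core of compound 1, which carries a methoxy group.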